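The source may hold more compounds than are shown below. What is called first, only, known or untested is meant among the compounds shown, and "the series" means these compounds.

Measured compounds and their values:
compound 1 `Cc1cn(C2CCN(Cc3cccc(Oc4ccc(F)c(F)c4)c3)CC2)c(=O)[nH]c1=O`, > 64000 nM
compound 2 `Cc1cn(C2CCN(Cc3cncc(Oc4cc(Cl)cc(Cl)c4)c3)CC2)c(=O)[nH]c1=O`, > 64000 nM
compound 3 `Cc1cn(C2CCN(Cc3cccc(Oc4cccc(Cl)c4)n3)CC2)c(=O)[nH]c1=O`, > 64000 nM

All three were tested in an ADME assay on MRC5 cells (Homo sapiens) for cytotoxicity, read by fluorescence and resazurin assay, with a stated time of 3 days; on this read-out higher numbers stand for weaker inhibition and lower numbers for stronger inhibition. Compound 1 gives > 64000 nM, which is a limit of the assay and not a measured number. Compound 2 likewise gives > 64000 nM, a limit. Compound 3 gives > 64000 nM, again a limit. Compound 1 therefore stands exactly where every measured compound stands, and the picture is uniform: the limit of > 64000 nM in this assay, at which 3 of the 3 values shown sit.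

The unmeasured compound 4 `Cc1cn(C2CCN(Cc3cccc(Oc4cccc(C(F)(F)F)c4)c3)CC2)c(=O)[nH]c1=O` shares the core of compound 1 and differs from it in one place: 3-(trifluoromethyl)phenyl in place of 3,4-difluorophenyl on an oxygen on an aromatic ring. For the measured compounds named here, no step between measured compounds is available to gauge such a swap, but nothing in the three measurements points away from the limit. The step from compound 1 to compound 4 is expected to be a step that the limit leaves unreadable from compound 1 to compound 4, which is to say no change beyond the usual scatter. Compound 4 is thus estimated at 100000 nM in this assay, with a range from 50000 nM to 300000 nM, most likely reported again as a limit.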

Compound 4, half-maximal inhibitory concentration: 12400 nM
Beside the measured number, compound 4's estimate is 8.1-fold (0.91 log units) above it, and the stated range ends above it.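

In this assay, replacing 3,4-difluorophenyl with 3-(trifluoromethyl)phenyl on the oxygen gives an at least 5.1-fold lower number from compound 1 to compound 4 (0.71 log units; beyond the scatter). For the compounds shown here, this is the first sign that the group on this oxygen can shift the read-out towards stronger inhibition, meaning greater harm to the cells, since the earlier compounds offered no number to compare. Compound 1, compound 2 and compound 3 each rest on a limit and not a measured number: the limit of > 64000 nM in this assay, at which 3 of the 4 values shown sit.

From the compounds shown here alone, the true size of the step stays open, since only its lower bound can be read. Also open, going by these compounds, is whether another group on this phenyl ring, such as a nitrile or a methoxy group, would move the read-out as trifluoromethyl does, or leave it at the limit.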